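Oral Exposure in Mice: From Methoxy to Trifluoromethyl

The source may hold more compounds than are shown below. What is called first, only, known or untested is meant among the compounds shown, and "the series" means these compounds.

In an ADME assay on the whole organism (Mus musculus, strain CD1) for pharmacokinetics, at a dose of 10 mg/kg by the oral route (on this read-out higher numbers stand for higher exposure at the dose given and lower numbers for lower exposure), compound 1 (`COc1cc(N2C(=O)C3(CCC3)N(c3ccc(OC4CCN(C)CC4)nc3)C2=S)cnc1C#N`) gives 6100 ng.h/mL and compound 2 (`CN1CCC(Oc2ccc(N3C(=S)N(c4cnc(C#N)c(C(F)(F)F)c4)C(=O)C34CCC4)cc2)CC1`) gives 9400 ng.h/mL. Among the measured compounds shown here, compound 1 thus stands within the scatter of the only other measured compound. Compound 3 (`CN1CCC(Oc2ccc(N3C(=S)N(c4cnc(C#N)c(C(F)(F)F)c4)C(=O)C34CCC4)cn2)CC1`) has not yet been measured in this assay. It differs from compound 1 by trifluoromethyl in place of methoxy on an aromatic carbon, ortho to a cyano group (trifluoromethyl in place of methoxy on an aromatic carbon), which turns 6-cyano-5-methoxypyridin-3-yl into 6-cyano-5-(trifluoromethyl)pyridin-3-yl. For the measured compounds named here, no measured pair isolates this change, so the expectation rests only on the narrow span of the two known values, with compound 2 at 9400 ng.h/mL. The step of a 1.3-fold higher number from compound 1 to compound 3 (0.12 log units; within the scatter) is expected to point slightly upward and to stay within the scatter. For compound 3, the estimated exposure is 8000 ng.h/mL, with an expected range of 3500 ng.h/mL to 18000 ng.h/mL.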

Compound 3, area under the concentration-time curve: 10900 ng.h/mL
The estimate for compound 3 lay 1.4-fold (0.13 log units) below the measured number; measured number inside the range.
By their numbers in this assay, from the lowest: compounds 1, 2 and 3 (each within the scatter of the next).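

In this assay, the change can now be read on its own, as a 1.8-fold higher number from compound 1 to compound 3 (0.25 log units; within the scatter), with trifluoromethyl in place of methoxy on an aromatic carbon ortho to a cyano group. At this place, then, four heavy atoms and no hydrogen-bond acceptor stand where methoxy had two heavy atoms and one, and the step does not clear the scatter; the position accepts either group without a difference that can be told apart in oral exposure. Nothing shown bears on what lies behind this result.

As far as these compounds go, this reading rests on a single pair, so it remains open whether the same change would give the same step elsewhere on the shared core. Also open, from the compounds shown here alone, is whether an amine, a carboxylic acid or a longer alkyl chain at this place would step beyond the scatter.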